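Nitro in Place of Trifluoromethyl on a Urea Series

A few compounds are considered here, and "the series" means these few. Any claim that something is new, unique, unknown or untested is made for them only; others in the source may bear on it.

Compound 1 `O=C(Nc1cccc(Br)c1)N1CCN(c2ccnc(Cl)n2)CC1`: 1450 nM
Compound 2 `O=C(Nc1ccc(F)cc1)N1CCN(c2ccnc(Cl)n2)CC1`: 1140 nM
Compound 3 `O=C(Nc1ccccc1C(F)(F)F)N1CCN(c2ccnc(Cl)n2)CC1`: 136 nM

All three share one core and differ only in the aryl group on the urea nitrogen. In an assay on isolated protein for antagonist activity at transient receptor potential cation channel subfamily V member 1 (Homo sapiens) (a higher number here means a weaker inhibitor, a lower number a stronger inhibitor), compound 3 stands lowest of the three; compound 2 and compound 1 give higher numbers, both beyond the scatter. Compound 4 `O=C(Nc1ccccc1[N+](=O)[O-])N1CCN(c2ccnc(Cl)n2)CC1` carries nitro in place of trifluoromethyl on an aromatic carbon. Among the compounds with values here, the one step between measured compounds, a 1.3-fold lower number from compound 1 to compound 2 (0.10 log units; within the scatter), moves a halogen between other positions and does not bear on this change. Within the data shown here, no measured pair compares two different groups at this position. The expected step is a 2.9-fold higher number from compound 3 to compound 4 (0.47 log units; beyond the scatter), a modest loss. The estimate for compound 4 is 400 nM, within 100 nM to 1600 nM.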

Compound 4, half-maximal inhibitory concentration: 854 nM
Estimate against measurement, compound 4: 2.1-fold (0.33 log units) below; the range from low to high includes it.
By their numbers in this assay, from the lowest: compound 3; then compounds 4, 2 and 1 (each within the scatter of the next).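

Within the data shown here, putting nitro in place of trifluoromethyl on this aromatic carbon gives a 6.3-fold higher number from compound 3 to compound 4 (0.80 log units; beyond the scatter) and so provides the first measured pair with two different groups at this position. The position therefore responds to the choice of group, and here trifluoromethyl gives the stronger inhibitor of the pair. No available evidence explains the difference. On these data alone, it remains open how other groups at this place, such as an amine, a carboxylic acid or a methoxy group, would compare with these two.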